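Fluoro on the phenyl arm of the unsubstituted core

The source may report more compounds than this note shows. Statements on the series, on what has been measured and on what is new or still open speak of the compounds shown alone.

Compound 1 `COC(=O)c1sc2cc(OC)ccc2c1C#Cc1ccccc1` gives 79600 nM in a functional assay on MCF7 cells (Homo sapiens) for cytotoxicity, read by sulforhodamine B assay, with a stated time of 48 h; on this read-out lower numbers stand for stronger inhibition of growth and higher numbers for weaker inhibition of growth. Compound 2 `COC(=O)c1sc2cc(OC)ccc2c1C#Cc1ccc(F)cc1` gives 12600 nM in this assay, and the step is a 6.3-fold lower number from compound 1 to compound 2 (0.80 log units; beyond the scatter). Compound 3 `COC(=O)c1sc2ccccc2c1C#Cc1ccccc1`, the same core without the methoxy group, gives 71600 nM in this assay; here a 1.1-fold lower number from compound 1 to compound 3 (0.05 log units; within the scatter), so compound 3 and compound 1 sit together, and compound 3 holds the second highest number of the three, with compound 2 well below it.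

Compound 4 `COC(=O)c1sc2ccccc2c1C#Cc1ccc(F)cc1` differs from compound 3 by fluoro in place of hydrogen on an aromatic carbon. Among the measured compounds shown here, the only measured step that bears on this change is the same substitution made on the methoxy-bearing core, where a 6.3-fold lower number from compound 1 to compound 2 (0.80 log units; beyond the scatter), a modest step beyond the scatter. Nothing shows that the methoxy group alters the effect of the fluoro, so a step of similar size, downward, is expected for compound 4, namely a 6.0-fold lower number from compound 3 to compound 4 (0.78 log units; beyond the scatter). On this basis compound 4 is estimated at 12000 nM in this assay, with a range from 5000 nM to 30000 nM.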

Compound 4, concentration for 50% growth inhibition: 60600 nM
Compound 4: the middle estimate sits 5.1-fold (0.70 log units) below what was measured; measured number outside the range, above it.
By their numbers in this assay, from the lowest: compound 2; then compounds 4, 3 and 1 (each within the scatter of the next).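

Phenyl to 4-fluorophenyl does not carry over between the two cores in this assay; on the core without methoxy it gives a 1.2-fold lower number from compound 3 to compound 4 (0.07 log units; within the scatter): the same change on two cores in this assay, a 6.3-fold lower number (0.80 log units; beyond the scatter) from compound 1 to compound 2 and a 1.2-fold lower number (0.07 log units; within the scatter) from compound 3 to compound 4, 5.3-fold (0.73 log units) apart, beyond the scatter of two such steps. Read the other way, hydrogen in place of methoxy on the fluoro-bearing core gives a 4.8-fold higher number from compound 2 to compound 4 (0.68 log units; beyond the scatter), whereas the same change left compound 1 and compound 3 within the scatter of each other: the same change on two cores in this assay, a 1.1-fold lower number (0.05 log units; within the scatter) from compound 1 to compound 3 and a 4.8-fold higher number (0.68 log units; beyond the scatter) from compound 2 to compound 4, 5.3-fold (0.73 log units) apart, beyond the scatter of two such steps. Among the compounds shown here, the two groups therefore count only together in these four compounds: compound 2, the one compound carrying both, stands apart from the other three.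

From the compounds shown here alone, whether the lower number of compound 2 needs methoxy itself, or would also appear with a hydroxyl or an amine at that place on the core, remains open. Equally open, going by these compounds, is whether a chloro in place of the fluoro on the phenyl arm would behave the same way on either core.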